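Trading a fluorophenyl for tert-butyl at the ring nitrogen

The source may report more compounds than this note shows. Statements on the series, on what has been measured and on what is new or still open speak of the compounds shown alone.

Compound 1 `[O-][S+](CCNC1CCN(Cc2ccc(F)cc2)CC1)C(c1ccc(F)cc1)c1ccc(F)cc1` is measured in an assay on membranes from striatum (strain Sprague-Dawley) for displacement of a labelled ligand from sodium-dependent dopamine transporter (Rattus norvegicus), read by scintillation counting, with a stated time of 120 min (on this read-out lower numbers stand for stronger inhibition and higher numbers for weaker inhibition), where compound 1 gives 50.6 nM. Among the three measured compounds this is the second highest number. Compound 2 `OC(Cc1ccccc1)CN1CCC(NCCSC(c2ccc(F)cc2)c2ccc(F)cc2)CC1` gives 31.4 nM, which lies within the scatter of compound 1. Compound 3 `CC(C)(C)C(=O)N1CCC(NCCSC(c2ccc(F)cc2)c2ccc(F)cc2)CC1` gives 352 nM, a number clearly above that of compound 1. Going by the values given here, the single measured step, an 11-fold higher number from compound 2 to compound 3 (1.05 log units; beyond the scatter), swaps the group on the ring amine nitrogen and removes its aromatic ring, though it also turns that nitrogen into an amide. Compound 4 `CC(C)(C)CN1CCC(NCC[S+]([O-])C(c2ccc(F)cc2)c2ccc(F)cc2)CC1` is not yet measured; it differs from compound 1 by tert-butyl in place of 4-fluorophenyl on a saturated chain carbon bound to an amine nitrogen in a ring, so the 4-fluorobenzyl on the ring nitrogen becomes neopentyl while the nitrogen stays an amine. The step from compound 2 to compound 3 bears on this only partly, and it is large, which makes a weakening the more likely direction. Compound 4 is therefore expected to show a moderately higher number, a 2.4-fold higher number from compound 1 to compound 4 (0.38 log units; beyond the scatter). The estimate for compound 4 is 120 nM, within 40 nM to 400 nM.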

Compound 4, inhibition constant: 431 nM
Beside the measured number, compound 4's estimate is 3.6-fold (0.56 log units) below it; the whole stated range lies below it.
By their numbers in this assay, from the lowest: compounds 2 and 1 (each within the scatter of the next); then compounds 3 and 4 (each within the scatter of the next).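

In this assay, the change from 4-fluorobenzyl to neopentyl gives an 8.5-fold higher number from compound 1 to compound 4 (0.93 log units; beyond the scatter), and the ring nitrogen stays an amine on both sides of this step. The earlier step, an 11-fold higher number from compound 2 to compound 3 (1.05 log units; beyond the scatter), also removed an aromatic ring, but it turned that nitrogen into an amide at the same time, so it could not show a rise beyond the scatter with the amine kept. Nothing measured here explains why the number rises.

From the compounds shown here alone, whether the loss follows the aromatic ring or its fluorine stays open, and a plain phenyl or a cyclohexyl on the same saturated chain carbon would help separate the two. How a longer chain ending in tert-butyl would behave at this place is also unknown.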